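Hydroxy for methoxy: expected cytotoxicity of compound 3

A few compounds are considered here, and "the series" means these few. Any claim that something is new, unique, unknown or untested is made for them only; others in the source may bear on it.

In an ADME assay on MDCK cells (Canis lupus familiaris) for cytotoxicity, read by MTT assay, with a stated time of 48 h (on this read-out lower numbers stand for higher toxicity in this test and higher numbers for lower toxicity in this test), the two measured compounds stand as follows.
Compound 1 `COc1ccc([C@H]2CC(C)(O)[C@@H]3CC[C@@H](C)C[C@H]3O2)cc1OC` gives > 937000 nM, which is a limit of this assay and not a number.
Compound 2 `COc1ccc([C@H]2CC(C)(O)[C@@H]3CC[C@@H](C)C[C@H]3O2)c(OC)c1OC` gives > 857000 nM, likewise a limit of this assay.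

Compound 1 therefore stands only at a limit, and the step that the two limits leave unreadable from compound 1 to compound 2 cannot be read, since both values sit at limits the limit of > 857000 nM in this assay, at which 1 of the 2 values shown sits (the limit of > 937000 nM in this assay, at which 1 of the 2 values shown sits). Compound 3 `COc1cc([C@H]2CC(C)(O)[C@@H]3CC[C@@H](C)C[C@H]3O2)ccc1O` differs from compound 1 by hydrogen in place of methyl on an oxygen on an aromatic ring. Within the data shown here, no measured step bears on this change, so no step beyond the scatter is expected in this assay; compound 3 is estimated at 900000 nM, within 300000 nM to 2000000 nM, an expected step of an at least 1.0-fold lower number from compound 1 to compound 3 (0.01 log units; that floor lies within the scatter).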

Compound 3, half-maximal cytotoxic concentration: 411000 nM
Compound 3: middle estimate off by 2.2-fold (0.34 log units), on the high side; the measured number falls inside the stated range.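

In this assay, hydrogen in place of methyl on an oxygen on an aromatic ring gives an at least 2.2-fold lower number from compound 1 to compound 3 (0.35 log units; beyond the scatter), so this methoxy to hydroxy change moves the read-out beyond the scatter. Compound 3 is the only compound shown with a number and not a limit, so the step has a floor but no readable full size: the limit of > 937000 nM in this assay, at which 1 of the 3 values shown sits. Compound 2 also stands only at a limit: the limit of > 857000 nM in this assay, at which 1 of the 3 values shown sits.

The compounds shown leave open whether an amine or a longer alkoxy chain at this place would also lower the number. They also leave open whether the same change at the other methoxy of compound 1 would give a similar step.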